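The source may report more compounds than this note shows. Statements on the series, on what has been measured and on what is new or still open speak of the compounds shown alone.

In a functional assay on OVCAR-3 cells (Homo sapiens) for antiproliferative activity (a lower number here means a stronger inhibitor of growth, a higher number a weaker inhibitor of growth), compound 3 `COC(=O)c1cc(/C=C\c2cc(OC)ccc2OC)ccc1OC`, a methyl ester, gives 4900 nM. Compound 2 `CCCCCCNC(=O)c1cc(/C=C\c2cc(O)ccc2O)ccc1O` gives 1700 nM, a lower number by a gap beyond the scatter of repeated measurements, which leaves compound 3 higher of the two exact values. Compound 1 `CCCCCCNC(=O)c1cc(C#Cc2cc(OC)ccc2OC)ccc1OC` gives > 100000 nM, which is a limit of the assay and not a number.

Compound 4 `CCCCCCNC(=O)c1cc(/C=C\c2cc(OC)ccc2OC)ccc1OC` keeps the core of compound 3 but has hexylamino in place of methoxy on a carbonyl carbon. Going by the values given here, no measured pair isolates this change, so the expectation is uncertain. The resulting hexylcarbamoyl group also occurs in compound 2, which gives 1700 nM, so a modest move towards a lower number seems more likely than a large one. Compound 1 carries the same group, yet its result is only a limit, so the range must stay wide on the upper side. The expected step of a 2.0-fold lower number from compound 3 to compound 4 (0.29 log units; within the scatter) in this assay is small. For compound 4 the estimated value is 2500 nM, with an expected range of 300 nM to 20000 nM.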

Compound 4, concentration for 50% growth inhibition: 16100 nM
The estimate for compound 4 lay 6.4-fold (0.81 log units) below the measured number, within the range that was stated.
By their numbers in this assay, from the lowest: compound 2; then compound 3; then compound 4. At a limit, above all of these: compound 1.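

Going by these compounds alone, compounds 3 and 4 form the first pair here that differs in only one place, so this change can be read on its own. In this assay the change from methoxycarbonyl to hexylcarbamoyl on the otherwise unchanged core gives a 3.3-fold higher number from compound 3 to compound 4 (0.52 log units; beyond the scatter) and so weakens growth inhibition modestly, even though the hexylamino part is the larger of the two groups. Compound 1 also carries hexylcarbamoyl, but its result is a limit and not a number, so it adds no second reading of this group: the limit of > 100000 nM in this assay, at which 1 of the 4 values shown sits.

From the compounds shown here alone, with a single replacement to read, it remains open whether a shorter chain such as ethylamino, a longer chain or a carboxylic acid would fall above or below the methyl ester. Going by these compounds, the cause of the step also remains open, as does whether it would hold on the hydroxy-bearing core of compound 2.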